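This account rests on a few compounds, and the source may have more. Where it says the series, first, only, none or still open, it means among the compounds named here.

Compound 1 `CCc1cc2[nH]ncc2cc1-c1ccccc1C(F)(F)F`: 50 nM
Compound 2 `CC(C)c1cc2[nH]ncc2cc1-c1ccccc1C(F)(F)F`: 25400 nM
Compound 3 `COc1cc2[nH]ncc2cc1-c1ccccc1C(F)(F)F`: 26 nM

In an assay on CHO-TREX cells for antagonist activity at transient receptor potential cation channel subfamily A member 1 (Homo sapiens), read by FLIPR and calcium flux, with a stated time of 10 min (a lower number here means a stronger inhibitor, a higher number a weaker inhibitor), compound 3 gives the lowest number of the three: the step of a 1.9-fold lower number from compound 1 to compound 3 (0.28 log units; within the scatter) lies within the scatter, while the step of a 980-fold lower number from compound 2 to compound 3 (2.99 log units; beyond the scatter) is large. Compound 4 `N#Cc1cc2[nH]ncc2cc1-c1ccccc1C(F)(F)F` differs from compound 3 by cyano in place of methoxy on an aromatic carbon. Two measured steps at this same position bear on the change: a 1.9-fold lower number from compound 1 to compound 3 (0.28 log units; within the scatter) shows that exchanging one small group for another hardly moves the number, whereas a 510-fold higher number from compound 1 to compound 2 (2.71 log units; beyond the scatter) shows that not every change here is harmless. Since cyano, like methoxy, is a short group without branching, only a small step is expected, a 2.3-fold higher number from compound 3 to compound 4 (0.36 log units; beyond the scatter), possibly a slight loss. Compound 4 is therefore estimated at 60 nM, within a range from 15 nM to 250 nM.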

Compound 4, half-maximal inhibitory concentration: 129 nM
For compound 4 the middle estimate is 2.2-fold (0.33 log units) below the measured one; measured number inside the range.
By their numbers in this assay, from the lowest: compounds 3 and 1 (each within the scatter of the next); then compound 4; then compound 2.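

Being small and unbranched is not enough at this position: the step of a 5.0-fold higher number from compound 3 to compound 4 (0.70 log units; beyond the scatter) and the step of a 2.6-fold higher number from compound 1 to compound 4 (0.41 log units; beyond the scatter) are both modest losses, so cyano does less well here than methoxy or ethyl. That loss remains minor beside the step of a 200-fold lower number from compound 2 to compound 4 (2.29 log units; beyond the scatter), which places cyano far ahead of isopropyl. Nothing measured here explains why cyano differs from methoxy. As far as these compounds go, it remains open how a lone chlorine atom, an amine or a longer chain such as propyl would fare in this position.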